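Replacing a hydroxyethyl chain with a difluoromethoxyphenyl group

The compounds below may be only part of what the source reports. "The series", "measured", "known", "first", "only" and "open" are said of these compounds alone.

The measured compounds:
Compound 1 `CCc1ccc2[nH]c(=O)c(CN(Cc3ccc(F)cc3)Cc3ccc4ccccc4c3)cc2c1`: in a toxicity assay on MDCK cells (Canis lupus familiaris) for cytotoxicity, read by crystal violet staining, with a stated time of 48 h (a lower number here means that less compound is tolerated, a higher number that more compound is tolerated), compound 1 gives > 5000 nM, a limit of the assay.
Compound 2 `Cc1ccc2[nH]c(=O)c(CN(CCCO)Cc3ccc(C(C)(C)C)cc3)cc2c1`: in this assay compound 2 gives > 10000 nM, a limit of the assay.
Compound 3 `CCc1ccc2[nH]c(=O)c(CN(CCCO)Cc3ccc(C(C)(C)C)cc3)cc2c1`: in this assay compound 3 gives > 10000 nM, a limit of the assay.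

Compound 2 thus stands at a limit, with no number of its own. Two of the three values sit at the limit of > 10000 nM in this assay, at which 2 of the 3 values shown sit, and one at the limit of > 5000 nM in this assay, at which 1 of the 3 values shown sits. Among the measured compounds shown here, the only single-point step, a step that the two limits leave unreadable from compound 2 to compound 3, is a methyl in place of hydrogen on a saturated chain carbon bound to an aromatic carbon, and it cannot be read because both ends are limits.

Compound 4 `Cc1ccc2[nH]c(=O)c(CN(Cc3ccc(OC(F)F)cc3)Cc3ccc(C(C)(C)C)cc3)cc2c1` differs from compound 2 by 4-(difluoromethoxy)phenyl in place of 2-hydroxyethyl on a saturated chain carbon bound to an amine nitrogen. For the measured compounds named here, no measured step covers this change, so the expectation rests only on the fact that every value shown, including that of compound 1, which carries two benzyl-type groups on the amine nitrogen, sits at a limit. Compound 4 is therefore expected to be tolerated at about 10000 nM in this assay, with a range from 3000 nM to 30000 nM. The expected step is a number no higher from compound 2 to compound 4 (the limit leaves the size open), within the scatter.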

Compound 4, half-maximal cytotoxic concentration: > 5000 nM
Compound 4: only a limit was reported; the forecaster's own chance of this, stated with the estimate: 65%; the middle value does not contradict the limit.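

In this assay compound 4 gives > 5000 nM, a limit of the assay. Among the compounds shown here, compound 2 gives > 10000 nM, also a limit, and no step between these two compounds can be read. The compounds shown leave open the concentration at which any of them becomes cytotoxic.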